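The source may report more compounds than this note shows. Statements on the series, on what has been measured and on what is new or still open speak of the compounds shown alone.

Of the compounds shown here, two sharing one core have been read in a physicochemical assay for solubility, read by nephelometry, measured as kinetic solubility, with a stated time of 30 min, at pH 2.0; a lower number here means a less soluble compound, a higher number a more soluble compound. Compound 1 (`O=C(O)COc1ccc([C@H]2CC[C@]3(CC2)OOC2(O3)C3CC4CC(C3)CC2C4)cc1C(=O)O`) gives > 100 ug/mL, which is a limit of the assay and not a number. Compound 2 (`CCOC(=O)COc1ccc([C@H]2CC[C@]3(CC2)OOC2(O3)C3CC4CC(C3)CC2C4)cc1`) gives < 0.78 ug/mL, also a limit and not a number, and it stands at the low end of the two readings. Compound 3 (`O=C(O)CCCOc1ccc([C@H]2CC[C@]3(CC2)OOC2(O3)C3CC4CC(C3)CC2C4)cc1`) has the same atoms as compound 2, joined differently: 2-carboxyethyl in place of ethoxycarbonyl on a saturated chain carbon bound to an oxygen on an aromatic ring. Thus 2-carboxyethyl takes the place of ethoxycarbonyl on a saturated chain carbon bound to an oxygen on an aromatic ring. Among the measured compounds shown here, no measured step covers this change, so the expectation is tentative. A modest rise in this assay, beyond the usual scatter, is expected, estimated as an at least 3.8-fold higher number from compound 2 to compound 3 (0.58 log units; beyond the scatter). For compound 3 the expected value is 3 ug/mL, with an estimated range of 0.78 ug/mL to 25 ug/mL.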

Compound 3, solubility: < 1.6 ug/mL
Compound 3: only a limit was reported (the forecaster's own chance of this, stated with the estimate: 30%); middle value at least 1.8-fold (0.27 log units) away from the limit.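

Among the compounds shown here, the readings of compound 2 and compound 3 in this assay are both limits and not numbers, so no step between them can be read. The compounds shown leave open whether 2-carboxyethyl in place of ethoxycarbonyl changes the reading at all, and by how much.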